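A few compounds are considered here, and "the series" means these few. Any claim that something is new, unique, unknown or untested is made for them only; others in the source may bear on it.

Compound 1 `CCOC(=O)c1ccc2oc(N3CCN(C)CC3)nc2c1`: in a functional assay on ileum (strain Hartley) for agonist activity at 5-hydroxytryptamine receptor 3A (Cavia porcellus) (on this read-out lower numbers stand for lower potency and higher numbers for higher potency (the scale is a negative logarithm)), compound 1 gives < 4, which is a limit of the assay and not a number.
Compound 2 `CN1CCN(c2nc3cccc(Cl)c3o2)CC1`: compound 2 gives 5.5.
Compound 3 `CN1CCN(c2nc3cc(C(C)(C)C)ccc3o2)CC1`: compound 3 gives < 4, which is again a limit of the assay and not a number.

Compound 3 therefore stands at the floor of what this assay reports, with no number of its own; it shares that position with compound 1, since (the limit of < 4 in this assay, at which 2 of the 3 values shown sit). Among the compounds with values here, the one measured step that touches the same place on the shared core, a step that the two limits leave unreadable from compound 1 to compound 3, runs between two limits and its size cannot be read.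

Compound 4 `COc1ccc2oc(N3CCN(C)CC3)nc2c1` differs from compound 3 in one place: methoxy in place of tert-butyl on an aromatic carbon. Within the data shown here, no measured step shows what a methoxy group does on this ring position, so the expectation for compound 4 rests only on where compound 3 stands and on the fact that a substituent exchange at this position has so far left both measured compounds at the limit. The step of a number at least 0.20 log units higher from compound 3 to compound 4 (that floor lies within the scatter) is therefore expected to be small and uncertain in direction. Compound 4 is estimated at 4.2, within a range from 3.5 to 5, with a real chance that this assay again reports only a limit.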

Compound 4, negative logarithm of the half-maximal effective concentration: 4.78
The estimate for compound 4 lay 0.58 log units below the measured number; measured number inside the range.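

Replacing tert-butyl with methoxy on this aromatic carbon in this assay gives a number at least 0.78 log units higher from compound 3 to compound 4 (beyond the scatter), and replacing ethoxycarbonyl with methoxy gives a number at least 0.78 log units higher from compound 1 to compound 4 (beyond the scatter). The position therefore does not hold every compound at the floor of the assay: until now both groups measured here had left only a limit, whereas methoxy, with fewer heavy atoms than either, gives a real number. Both steps start from a limit, so their true sizes remain unknown, and the step between the two compounds at the limit cannot be read at all: the limit of < 4 in this assay, at which 2 of the 4 values shown sit.

With only one group giving a number at this position, the compounds shown leave open whether a hydroxyl, an amine or a longer ether chain such as ethoxy would keep, raise or lose this response. Going by these compounds, compound 2 differs from compound 4 in more than one place, so it also remains open what methoxy would do on a core that already gives a number without it.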